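The compounds below may be only part of what the source reports. "The series", "measured", "known", "first", "only" and "open" are said of these compounds alone.

Measured in a functional assay on MCF7 cells (Homo sapiens), read by colorimetric assay, with a stated time of 96 h; a lower number here means a stronger inhibitor, a higher number a weaker inhibitor:
- Compound 1 `OC[C@@H](O)[C@H]1O[C@@H](n2cnc3c(Cl)nc(Cl)nc32)[C@H](O)[C@@H]1O` gives 54200 nM.
- Compound 2 `Nc1nc(Cl)nc2c1ncn2[C@@H]1O[C@H]([C@H](O)CO)[C@@H](O)[C@H]1O` gives > 100000 nM, which is a limit of the assay and not a number.
- Compound 3 `CC(=O)OC[C@@H](OC(C)=O)[C@H]1O[C@@H](n2cnc3c(Cl)nc(Cl)nc32)[C@H](OC(C)=O)[C@@H]1OC(C)=O` gives 22400 nM.

For the measured compounds named here, compound 1 and compound 2 share one core, and the only change between them is amino in place of chloro on an aromatic carbon. That change made a step of an at least 1.8-fold higher number from compound 1 to compound 2 (0.26 log units; that floor lies within the scatter); its size is known only as a floor because of the limit of > 100000 nM in this assay, at which 1 of the 3 values shown sits. Compound 3 carries a different core, and the difference between the core of compound 1 and that of compound 3 is not broken down here. Of the two numbers in this assay, compound 3 shows the lower one, and its gap to compound 1 lies beyond the scatter.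

Compound 4 `CC(=O)OC[C@@H](OC(C)=O)[C@H]1O[C@@H](n2cnc3c(N)nc(Cl)nc32)[C@H](OC(C)=O)[C@@H]1OC(C)=O` has not yet been measured. Going by the values given here, it differs from compound 3 by amino in place of chloro on an aromatic carbon, which is the same change as the one from compound 1 to compound 2, with the place described in the same words. The step is therefore expected to be a 2.7-fold higher number from compound 3 to compound 4 (0.43 log units; beyond the scatter) in this assay, resting on an at least 1.8-fold higher number from compound 1 to compound 2 (0.26 log units; that floor lies within the scatter), although that earlier step is known only as a floor lying within the scatter, so the size is uncertain and a limit may again be reported. Compound 4 is estimated at 60000 nM, between 25000 nM and 200000 nM.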

Compound 4, half-maximal inhibitory concentration: > 100000 nM
Compound 4: a limit, no number; the forecaster's own chance of this, stated with the estimate: 30%; middle value at least 1.6-fold (0.22 log units) from the limit.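

In this assay compound 4 gives > 100000 nM, which is a limit of the assay and not a number. Amino in place of chloro on an aromatic carbon gives a step of an at least 4.4-fold higher number from compound 3 to compound 4 (0.64 log units; beyond the scatter), so on the core of compound 3 the change clearly goes with a weaker inhibitor, and the earlier step on the core of compound 1 points the same way, although its floor alone lies within the scatter. This shows that the direction of the change holds on these two cores, but it does not show that the size carries over from one core to the other: the same change on two cores in this assay, an at least 1.8-fold higher number (0.26 log units; that floor lies within the scatter) from compound 1 to compound 2 and an at least 4.4-fold higher number (0.64 log units; beyond the scatter) from compound 3 to compound 4; the limit leaves it open whether they differ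

Neither step has a known upper end, so the real size of the change remains open on both cores: the limit of > 100000 nM in this assay, at which 2 of the 4 values shown sit.
Going by these compounds, it also remains open whether a methoxy or a dimethylamino group in place of chloro on that same carbon would give a number that can be measured on either core.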